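The source may report more compounds than this note shows. Statements on the series, on what has been measured and on what is new or still open speak of the compounds shown alone.

Measured so far in a functional assay on the whole organism (Tail, strain ICR) with Mus musculus as the target, in the tail flick test, with a stated time of 30 min, at a dose of 25 umol/kg by the oral route; on this read-out lower numbers stand for a weaker effect and higher numbers for a stronger effect at the one dose given:
- compound 1 `O=C(OCc1ccccc1)[C@@H]1CCCN1C(=O)CN(c1nc(Cl)nc2[nH]cnc12)C1CC1` gives 33.2%
- compound 2 `NC(=O)CC[C@H](NC(=O)CN(c1ncnc2c1ncn2C1CCCCO1)C1CC1)C(=O)OCc1ccccc1` gives 47%

Of the two numbers, compound 2 is the higher, and the gap to compound 1 lies beyond the scatter. The two compounds do not differ in a single place, so no step can be read from them; the difference between them is only what the two values show.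

Compound 3 `O=C(CN(c1ncnc2c1ncn2C1CCCCO1)C1CC1)N[C@@H](CCC(=O)OCc1ccccc1)C(=O)OCc1ccccc1` is the next one to be run in this assay. It differs from compound 2 in one place: benzyloxy in place of amino on a carbonyl carbon. The rest of compound 2 is kept. Among the compounds with values here, no measured pair shows what such a change does, and compound 1 offers no one-place comparison to either. With nothing to lean on, the step of a number 5 percentage points lower from compound 2 to compound 3 (within the scatter) is expected to be small and to stay within the scatter, with no direction preferred. On that basis compound 3 is estimated at 42%, with a range from 20% to 65%; the width of the range reflects the absence of any comparable step.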

Compound 3, a percentage reported as activity, at one dose (the size of the read-out at that dose, not a potency): 32.6%
The estimate for compound 3 lay 9.4 percentage points above the measured number; the measured number falls inside the stated range.
By their numbers in this assay, from the lowest: compounds 3 and 1 (each within the scatter of the next); then compound 2.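

In this assay the series now has its first one-place step: benzyloxy in place of amino on a carbonyl carbon gives a number 14.4 percentage points lower from compound 2 to compound 3 (beyond the scatter). The read-out at the one dose given therefore responds to what sits on this carbonyl carbon, but the change from 2-carbamoylethyl to 2-(benzyloxycarbonyl)ethyl alters several things at once: it removes the amino group with its hydrogen-bond donor and brings in a six-membered aromatic ring of carbon only, and a single step cannot separate these. No supporting measurement bears on the reason for the step.

As far as these compounds go, it remains open whether the lower number goes with the loss of the amino group or with the entering benzyloxy; a methoxy group or a hydroxy group on the same carbonyl carbon, giving a methyl ester or a carboxylic acid, would help to separate the two. Compound 1 has no one-place link to compound 2 or compound 3, so its relation to this step cannot be read.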